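Acyl change on the shared core: compound 2 to compound 3

The source may hold more compounds than are shown below. What is called first, only, known or untested is meant among the compounds shown, and "the series" means these compounds.

- compound 1 `CC1=NN(C(=O)CCl)C(c2cc(Br)ccc2O)C1` at 13500 nM
- compound 2 `CC1=NN(C(=O)c2ccc(C)cc2)C(c2cc(Br)ccc2O)C1` at 21000 nM

In a functional assay on MGC-803 cells (Homo sapiens) for cytotoxicity, read by MTT assay, with a stated time of 48 h (a lower number here means a stronger inhibitor, a higher number a weaker inhibitor), compound 2 stands at 21000 nM and compound 1 at 13500 nM with the two numbers within the scatter of each other. Compound 3 `CC1=NN(C(=O)CCc2ccccc2)C(c2cc(Br)ccc2O)C1` is not yet measured and carries the change phenethyl in place of 4-methylphenyl on a carbonyl carbon with phenethyl in place of 4-methylphenyl on a carbonyl carbon. Among the measured compounds shown here, one measured step bears on it: a 1.6-fold higher number from compound 1 to compound 2 (0.19 log units; within the scatter) on that same carbonyl carbon, with 4-methylphenyl in place of chloromethyl, and that step stays within the scatter. No step beyond the scatter is therefore expected in this assay and no direction is favoured. The expected move is a 1.2-fold lower number from compound 2 to compound 3 (0.07 log units; within the scatter) and no more. For the measured compounds named here, only two numbers support this, so the range is kept wide. For compound 3 the estimated value is 18000 nM with an expected range from 8000 nM to 40000 nM in this read-out.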

Compound 3, half-maximal inhibitory concentration: 21200 nM
Compound 3: the middle estimate sits 1.2-fold (0.07 log units) below what was measured; low and high end bracket the measured number.
By their numbers in this assay, from the lowest: compounds 1, 2 and 3 (each within the scatter of the next).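

Phenethyl in place of 4-methylphenyl on the carbonyl carbon gives a 1.0-fold higher number from compound 2 to compound 3 (0.00 log units; within the scatter) in this assay, so adding a phenyl-bearing chain here does not separate compound 3 from the aryl acyl group of compound 2. Benzyl in place of chloro on the saturated chain carbon gives a 1.6-fold higher number from compound 1 to compound 3 (0.20 log units; within the scatter), so the chloro group of compound 1 is not separated from this phenyl-bearing chain either, and all three acyl groups shown now lie within the scatter of one another. No measurement at hand accounts for this flat result.

Going by these compounds, whether this carbonyl carbon can carry any group that moves the number beyond the scatter remains open. An amine or a carboxylic acid at the end of the chain, or a longer chain, would test this in this assay.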